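Working notes on compound 4 in this cytotoxicity series

A few compounds are considered here, and "the series" means these few. Any claim that something is new, unique, unknown or untested is made for them only; others in the source may bear on it.

Compound 1 `CCOC(=O)c1cc2c(CN(C)C)c(O)c(OC)cc2nc1CSc1ccc(F)cc1`, compound 2 `CCOC(=O)c1cc2c(Cn3ccnc3)c(O)c(OC)cc2nc1CSc1ccc(F)cc1` and compound 3 `CCOC(=O)c1cc2c(CN3CCCC3)c(O)c(OC)cc2nc1CSc1ccc(F)cc1` share one core and differ only in the group on a saturated chain carbon bound to an aromatic carbon. In an ADME assay on HepG2 2.2.15 cells (Homo sapiens) for cytotoxicity, read by MTT assay, with a stated time of 9 days (a lower number here means that less compound is tolerated, a higher number that more compound is tolerated), compound 1 gives 120 uM, compound 2 gives 202 uM and compound 3 gives 47.3 uM. Compound 2 holds the highest number of the three: the step of a 1.7-fold higher number from compound 1 to compound 2 (0.23 log units; within the scatter) is within the scatter, whereas a 4.3-fold lower number from compound 2 to compound 3 (0.63 log units; beyond the scatter) and a 2.5-fold lower number from compound 1 to compound 3 (0.40 log units; beyond the scatter) are beyond it.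

Compound 4 `CCOC(=O)c1cc2c(Cn3ccnc3)c(O)c(OC)cc2nc1C[S+]([O-])c1ccc(F)c(F)c1` keeps the 1H-imidazol-1-yl group of compound 2 and alters a different part: a group of 10 heavy atoms (6 carbon, 1 oxygen, 2 fluorine, 1 sulfur; one six-membered aromatic ring of carbon only) in place of a group of 8 heavy atoms (6 carbon, 1 fluorine, 1 sulfur; one six-membered aromatic ring of carbon only), on a saturated chain carbon bound to an aromatic carbon. Among the measured compounds shown here, no measured step touches this part; all three concern the exchange of dimethylamino, 1H-imidazol-1-yl and pyrrolidin-1-yl. For compound 4 the expected step of a 1.1-fold lower number from compound 2 to compound 4 (0.03 log units; within the scatter) is therefore not beyond the scatter in either direction. Compound 4 is estimated at 190 uM, with a range from 80 uM to 420 uM.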

Compound 4, half-maximal toxic concentration: 90.8 uM
For compound 4 the middle estimate is 2.1-fold (0.32 log units) above the measured one; low and high end bracket the measured number.
By their numbers in this assay, from the lowest: compounds 3, 4, 1 and 2 (each within the scatter of the next, the first and the last beyond it).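

In this assay, the change to the group of 10 heavy atoms gives a 2.2-fold lower number from compound 2 to compound 4 (0.35 log units; beyond the scatter), so the number responds to this part as well as to the exchange of dimethylamino, 1H-imidazol-1-yl and pyrrolidin-1-yl. Oxygen and fluorine enter together in this one step, and their separate shares cannot be read from it. No measurement at hand accounts for the step.

Open, from the compounds shown here alone, is whether the oxygen or the added fluorine alone would give a step of this size. Also open, going by these compounds, is how a sulfonyl link or a pyridine ring would read at this place.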